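Lengthening the fluorinated chain on a triazole ether

The source may report more compounds than this note shows. Statements on the series, on what has been measured and on what is new or still open speak of the compounds shown alone.

Compound 1 `FC(F)(F)C(F)(F)C(F)(F)C(F)(F)C(F)(F)C(F)(F)CCn1cc(COc2ccccc2-c2nc3ccccc3s2)nn1` gives 11.9%.
Compound 2 `FC(F)(F)c1cccc(-n2cc(COc3ccccc3-c3nc4ccccc4s3)nn2)c1` gives 40.7%.
Compound 3 `COc1ccc(-c2nc3cc(F)ccc3s2)cc1OC` gives 27.2%.

In a functional assay on COLO 205 cells (Homo sapiens) for activation, read by flow cytometry, with a stated time of 24 h, tested at 16 uM (a lower number here means a weaker effect, a higher number a stronger effect of the compound at the concentration tested), compound 1 stands lowest of the three numbers. Compound 3 lies higher by a margin beyond the scatter, and compound 2 lies higher still, also beyond the scatter. Compound 4 `FC(F)(F)C(F)(F)C(F)(F)C(F)(F)C(F)(F)C(F)(F)C(F)(F)C(F)(F)CCn1cc(COc2ccccc2-c2nc3ccccc3s2)nn1` differs from compound 1 in one place: 1,1,2,2,2-pentafluoroethyl in place of fluoro on a saturated chain carbon bound to two fluorine atoms and a saturated chain carbon. Within the data shown here, no pair of measured compounds shows this change, so the expectation for compound 4 rests on compound 1 alone and on the small size of the change relative to the shared core. The step from compound 1 to compound 4 is expected to be none beyond the scatter, a number 0.9 percentage points lower from compound 1 to compound 4 (within the scatter) in this assay. Compound 4 is thus estimated at 11%, with a range from 2% to 22%.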

Compound 4, a percentage reported as activity, at one concentration (the size of the read-out at that concentration, not a potency): 34.5%
Compound 4: middle estimate off by 23.5 percentage points, on the low side; measured number outside the range, above it.
By their numbers in this assay, from the lowest: compound 1; then compounds 3, 4 and 2 (each within the scatter of the next, the first and the last beyond it).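

In this assay, 1,1,2,2,2-pentafluoroethyl in place of fluoro on a saturated chain carbon bound to two fluorine atoms and a saturated chain carbon gives a number 22.6 percentage points higher from compound 1 to compound 4 (beyond the scatter). Among these compounds, this is the first step between compounds differing in one place, and it shows that this position responds to a change adding no ring, hydrogen-bond donor, hydrogen-bond acceptor or net charge. No measurement shown gives a reason for this step.

From the compounds shown here alone, a single step sets no trend, so whether a still longer fluorinated chain would raise the number further stays open. Also open, going by these compounds, is how an amine or a carboxylic acid at this position would compare.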